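A few compounds are considered here, and "the series" means these few. Any claim that something is new, unique, unknown or untested is made for them only; others in the source may bear on it.

Results so far in an ADME assay on Vero cells (Chlorocebus sabaeus) for cytotoxicity, read by MTT assay; a higher number here means a weaker inhibitor, a lower number a stronger inhibitor:

Compound 1 `C=CCOc1cc(OC)c(C(=O)/C=C/C=C/c2ccccc2)c(OCC=C)c1`: "not determined" (no result reported)
Compound 2 `C=CCOc1cc(OC)c(C(=O)/C=C/c2ccc(OC)cc2)c(OCC=C)c1`: 99900 nM
Compound 3 `C=CCOc1cc(OC)c(C(=O)/C=C/c2ccc[nH]2)c(OCC=C)c1`: "not determined" (no result reported)

Compound 3 has no single number to place it on this scale. Compound 1 likewise has no result, so only compound 2 offers a measured value. The next compound to be tested is compound 4 `C=CCOc1cc(OC)c(C(=O)/C=C/c2ccc(Cl)cc2)c(OCC=C)c1` and it differs from compound 3 in one place. That change is 4-chlorophenyl in place of 1H-pyrrol-2-yl on a double-bonded chain carbon bound to a double-bonded chain carbon and it puts 4-chlorophenyl in place of 1H-pyrrol-2-yl on a double-bonded chain carbon bound to a double-bonded chain carbon.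

Going by the values given here, with no value for compound 3, the size of this step in this assay cannot be read from the data, and no measured step between related compounds is available as a guide. A single value is therefore the only anchor: compound 2 at 99900 nM in the same test. Without evidence for a large shift, the expectation is that compound 4 will land near that number, perhaps slightly lower, with no change beyond the usual scatter. For compound 4 the expected value is 70000 nM with an estimated range from 25000 nM to 150000 nM in this test.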

Compound 4, half-maximal inhibitory concentration: 10400 nM
Estimate against measurement, compound 4: 6.7-fold (0.83 log units) above, outside the stated range (below it).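

In this assay, going by these compounds alone, swapping methoxy for chloro on an aromatic carbon, with the rest of the molecule unchanged, gives a 9.6-fold lower number from compound 2 to compound 4 (0.98 log units; beyond the scatter), the first comparison between measured compounds. This shows that the result responds to a single group on that aromatic carbon, and that the shift is larger than repeat measurements alone would be expected to produce, so in this test the 4-chlorophenyl compound counts as the stronger inhibitor of the pair. Steps involving compound 1 or compound 3 cannot be read, so this comparison says nothing about replacing the 1H-pyrrol-2-yl group, and no further measurement here bears on why the number fell.

One step cannot show whether the shift is particular to chloro or would also appear with another group on that aromatic carbon, such as fluoro, trifluoromethyl, nitrile or an amine. It also leaves open whether plain phenyl, with neither methoxy nor chloro, would sit nearer to compound 2 or to compound 4 in this assay.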